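Compound 2 to compound 3: one ring exchanged

A few compounds are considered here, and "the series" means these few. Any claim that something is new, unique, unknown or untested is made for them only; others in the source may bear on it.

Values so far in a functional assay on MCF7 cells (Homo sapiens) for antiproliferative activity, read by MTT assay, with a stated time of 24 h (a higher number here means a weaker inhibitor, a lower number a stronger inhibitor), are these:
- Compound 1 `COC(=O)c1scc(-c2ccc(NC(=O)c3cccc(C(F)(F)F)c3)cc2)c1OC` gives 26200 nM as its value
- Compound 2 `COC(=O)c1scc(-c2ccc(NC(=O)c3ccc(F)c(Cl)n3)cc2)c1OC` gives 10300 nM as its value

Compound 2 holds the lower number at 10300 nM and is the stronger of this pair in this assay as measured so far. The change 2-fluoro-5-iodophenyl in place of 6-chloro-5-fluoropyridin-2-yl on a carbonyl carbon puts 2-fluoro-5-iodophenyl in place of 6-chloro-5-fluoropyridin-2-yl on a carbonyl carbon and gives compound 3 `COC(=O)c1scc(-c2ccc(NC(=O)c3cc(I)ccc3F)cc2)c1OC` as the compound still to be measured. Among the compounds with values here, one measured step bears on it: a 2.5-fold lower number from compound 1 to compound 2 (0.41 log units; beyond the scatter) on going from 3-(trifluoromethyl)phenyl to 6-chloro-5-fluoropyridin-2-yl. Compound 3 returns to a ring of carbon only, like compound 1 at 26200 nM and a move back toward that number is therefore expected. Within the data shown here, no measured compound carries 2-fluoro-5-iodophenyl, so the footing is thin. Among the measured compounds shown here, the expected change is a 1.6-fold higher number from compound 2 to compound 3 (0.19 log units; within the scatter) and it should be no larger than the one measured step. For compound 3 the estimated value is 16000 nM with an expected range from 6500 nM to 38000 nM in this assay.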

Compound 3, half-maximal inhibitory concentration: 22500 nM
For compound 3 the middle estimate is 1.4-fold (0.15 log units) below the measured one, within the range that was stated.
By their numbers in this assay, from the lowest: compound 2; then compounds 3 and 1 (each within the scatter of the next).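

In this assay, this place on the carbonyl carbon now has a second ring of carbon only, and 2-fluoro-5-iodophenyl does not hold the level of 6-chloro-5-fluoropyridin-2-yl: the exchange gives a 2.2-fold higher number from compound 2 to compound 3 (0.34 log units; beyond the scatter) in this series. Within the data shown here, the two rings of carbon only cannot be told apart, with a 1.2-fold lower number from compound 1 to compound 3 (0.07 log units; within the scatter), so 2-fluoro-5-iodophenyl and 3-(trifluoromethyl)phenyl stand together and compound 2, the only one here with a ring nitrogen, stands apart from both. Nothing available here explains that separation.

From the compounds shown here alone, whether the ring nitrogen itself matters stays open, as compound 2 and compound 3 also carry different halogens, and a plain phenyl or a 5-fluoropyridin-2-yl ring would separate these features. Going by these compounds, how an amine or a carboxylic acid on this ring would read in this assay also remains open.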